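The source may hold more compounds than are shown below. What is called first, only, known or untested is meant among the compounds shown, and "the series" means these compounds.

Measured so far:
compound 1, `COc1cc(-c2cc(/C=C/C(=O)c3ccc(Cl)c(Cl)c3)[nH]n2)cc(OC)c1OC`: 4900 nM in a functional assay on NCI-H460 cells (Homo sapiens) for inhibition, read by sulforhodamine B assay, with a stated time of 48 h; a lower number here means a stronger inhibitor of growth, a higher number a weaker inhibitor of growth
compound 2, `COc1ccc(C(=O)/C=C/c2cc(-c3cc(OC)c(OC)c(OC)c3)n[nH]2)cc1OC`: 1410 nM in this assay

Among the compounds with values here, compound 2 stands lowest of the two numbers; its nearest neighbour is compound 1, reached through the single step of a 3.5-fold lower number from compound 1 to compound 2 (0.54 log units; beyond the scatter). Compound 3, `COc1ccc(C(=O)/C=C/c2cc(-c3cc(OC)c(OC)c(OC)c3)n[nH]2)cc1`, differs from compound 2 by hydrogen in place of methoxy on an aromatic carbon. Within the data shown here, no measured step touches a methoxy group on this ring; the step from compound 1 to compound 2 swapped the whole aryl group and gives no direct guide. A small change, at most near the scatter and if anything towards a higher number, is expected; the estimated step is a 1.6-fold higher number from compound 2 to compound 3 (0.19 log units; within the scatter). Compound 3 is therefore expected at 2200 nM, range 800 nM to 6000 nM, in this assay.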

Compound 3, concentration for 50% growth inhibition: 1720 nM
For compound 3 the middle estimate is 1.3-fold (0.11 log units) above the measured one, within the range that was stated.
By their numbers in this assay, from the lowest: compounds 2 and 3 (each within the scatter of the next); then compound 1.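

In this assay the methoxy group ortho to the other methoxy can give way to hydrogen with the reading staying within the scatter (a 1.2-fold higher number from compound 2 to compound 3 (0.09 log units; within the scatter)). Within the data shown here, the single 4-methoxyphenyl group thus keeps a separation from 3,4-dichlorophenyl that lies beyond the scatter (a 2.8-fold lower number from compound 1 to compound 3 (0.45 log units; beyond the scatter)), so the second methoxy group is not required for it. Nothing measured here gives a reason for either step.
Open, on these data alone, is whether the remaining methoxy group on this ring matters at all, with plain phenyl as the direct test. Also open, as far as these compounds go, is how a hydroxyl group or an amine would read on this ring.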